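The source may report more compounds than this note shows. Statements on the series, on what has been measured and on what is new or still open speak of the compounds shown alone.

Of the compounds shown here, two have been tested in an assay on isolated protein for inhibition of CCR4-NOT transcription complex subunit 7 (Homo sapiens), read by fluorescence (a lower number here means a stronger inhibitor, a higher number a weaker inhibitor), and they share a core built around a fused aromatic ring system bearing two carbonyl groups. Compound 1 (`Cn1cnc2[nH]c(=O)n(O)c(=O)c21`) carries a hydroxy group on a ring nitrogen, and in this assay compound 1 gives 251000 nM, a weak result. Compound 2 (`C=CCOn1c(=O)[nH]c2ncn(Cc3ccccc3)c2c1=O`) instead carries a benzyl group on the ring and an allyloxy group on a ring nitrogen. In this assay compound 2 gives only a limit, > 1000000 nM, which marks the edge of what the measurement can report rather than a number; this is the case described by the limit of > 1000000 nM in this assay, at which 1 of the 2 values shown sits.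

Compound 3 (`O=c1[nH]c2ncn(Cc3ccccc3)c2c(=O)n1O`) has not yet been measured. It differs from compound 2 in one place: hydrogen in place of allyl on an oxygen on an aromatic ring. Put another way, the allyloxy group becomes a free hydroxy group, as in compound 1. Because compound 1 with its free hydroxy gives 251000 nM, a value in that region is expected for compound 3 rather than a limit. The expected outcome in this assay for compound 3 is about 300000 nM, estimated to lie between 100000 nM and 1000000 nM. This estimate means an expected step of an at least 3.3-fold lower number from compound 2 to compound 3 (0.52 log units; beyond the scatter), toward stronger inhibition.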

Compound 3, half-maximal inhibitory concentration: 10400 nM
Beside the measured number, compound 3's estimate is 29-fold (1.46 log units) above it; measured number below the stated range.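

In this assay, replacing the allyl group with hydrogen on the oxygen gives an at least 96-fold lower number from compound 2 to compound 3 (1.98 log units; beyond the scatter), so with the benzyl group held constant, the free hydroxy group is far preferred to the allyloxy group. On these data alone, the true size of this step remains unknown, because compound 2 gives only a limit and not a number: the limit of > 1000000 nM in this assay, at which 1 of the 3 values shown sits. Compounds 1 and 2 differ in more than one place and could not show this, whereas compound 3 also isolates the other change, with phenyl in place of hydrogen on the saturated chain carbon bound to an aromatic nitrogen turning the methyl group into a benzyl group and giving a 24-fold lower number from compound 1 to compound 3 (1.38 log units; beyond the scatter).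

The compounds shown leave open whether any group on that oxygen can be accepted, since a single allyl group cannot show whether a shorter one such as ethyl would fare better. They also leave open how far the gain from the benzyl group can be taken, for example with a longer phenylethyl chain or with a carboxylic acid or an amine on the phenyl ring.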